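The source may report more compounds than this note shows. Statements on the series, on what has been measured and on what is new or still open speak of the compounds shown alone.

Compound 1 `C=C[C@@](C)(/C=C/c1ccc(OS(=O)(=O)C(F)(F)F)cc1)CCC=C(C)C` is tested in a functional assay on NALM-6 cells (Homo sapiens) for cytotoxicity, with a stated time of 72 h; on this read-out higher numbers stand for an effect only at larger amounts of compound and lower numbers for an effect already at smaller amounts. In this assay compound 1 gives > 43400 nM, which is a limit of the assay and not a number. Compound 1 therefore stands at the limit of > 43400 nM in this assay, at which 2 of the 3 values shown sit. Compound 2 `C=C[C@@](C)(/C=C/c1ccc(OS(=O)(=O)c2ccc(C)cc2)cc1)CCC=C(C)C` gives > 43400 nM in this assay, again only a limit. The step from compound 1 to compound 2, a step that the two limits leave unreadable from compound 1 to compound 2, therefore cannot be read. Compound 3 `C=C[C@@](C)(/C=C/c1ccc(O)c(C=O)c1)CCC=C(C)C` gives 11200 nM in this assay. The unmeasured compound 4 `C=C[C@@](C)(/C=C/c1ccc(-c2ccc(Cl)c(Cl)c2)cc1)CCC=C(C)C` differs from compound 1 as follows: 3,4-dichlorophenyl in place of ((trifluoromethyl)sulfonyl)oxy on an aromatic carbon. Going by the values given here, none of the measured steps involves this change, so no measured step bears on it, and compound 3 alone shows that a number within range can occur. The expected step of an at least 2.8-fold lower number from compound 1 to compound 4 (0.46 log units; beyond the scatter) is estimated with low confidence. Compound 4 is expected to give about 15000 nM, between 4000 nM and 43400 nM.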

Compound 4, half-maximal effective concentration: > 43400 nM
Compound 4: no number, only a limit (the forecaster's own chance of this, stated with the estimate: 40%); at least 2.8-fold (0.46 log units) between middle value and limit.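

In this assay compound 4 gives > 43400 nM, a limit and not a number, so its step from compound 1, also a limit, cannot be read. The compounds shown leave open how either sulfonyl or aryl replacement changes the number, with most values at one limit: the limit of > 43400 nM in this assay, at which 3 of the 4 values shown sit.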